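The compounds below may be only part of what the source reports. "The series", "measured", "known", "first", "only" and "open" are said of these compounds alone.

Measured in a functional assay on HeLa cells (Homo sapiens) for inhibition, read by CCK-8 assay, with a stated time of 48 h; a higher number here means a weaker inhibitor, a lower number a stronger inhibitor:
- Compound 1 `COc1cc(-c2ccnc3cc(-c4ccc(C)cc4)nn23)cc(OC)c1OC`: 21 nM
- Compound 2 `COc1cc(-c2ccnc3cc(-c4cccc(C)c4)nn23)cc(OC)c1OC`: 4230 nM
- Compound 3 `COc1ccc(-c2cc3nccc(-c4cc(OC)c(OC)c(OC)c4)n3n2)cc1`: 373 nM

Compound 3 holds the middle place, with the second highest of the three numbers. Compound 4 `COc1cc(-c2ccnc3cc(-c4ccc(C(C)(C)C)cc4)nn23)cc(OC)c1OC` has tert-butyl in place of methoxy on an aromatic carbon, turning 4-methoxyphenyl into 4-(tert-butyl)phenyl (tert-butyl in place of methoxy on an aromatic carbon). The closest evidence is the large change an 18-fold higher number from compound 1 to compound 3 (1.25 log units; beyond the scatter), where methoxy replaces methyl. The large changes a 200-fold higher number from compound 1 to compound 2 (2.30 log units; beyond the scatter) and an 11-fold lower number from compound 2 to compound 3 (1.05 log units; beyond the scatter) show that small edits to this ring can shift the number strongly. Among the compounds with values here, no tert-butyl compound has been measured, so a moderate step towards a lower number is expected, a 1.9-fold lower number from compound 3 to compound 4 (0.27 log units; within the scatter). The estimated value for compound 4 is 200 nM, with an expected range of 25 nM to 1600 nM.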

Compound 4, half-maximal inhibitory concentration: > 10000 nM
Compound 4: a limit, no number (the forecaster's own chance of this, stated with the estimate: 3%); at least 50-fold (1.69 log units) between middle value and limit.
By their numbers in this assay, from the lowest: compound 1; then compound 3; then compound 2. At a limit, above all of these: compound 4.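

In this assay compound 4 gives > 10000 nM, which is a limit of the assay and not a number. Tert-butyl in place of methoxy gives an at least 26-fold higher number from compound 3 to compound 4 (1.42 log units; beyond the scatter), tert-butyl in place of methyl gives an at least 470-fold higher number from compound 1 to compound 4 (2.67 log units; beyond the scatter), and 4-(tert-butyl)phenyl in place of 3-methylphenyl gives an at least 2.3-fold higher number from compound 2 to compound 4 (0.37 log units; beyond the scatter). So at this place on the ring, methyl, methoxy and tert-butyl give rising numbers, and tert-butyl ends even past the poor 3-methylphenyl compound. Left open is how an ethyl group, a chlorine atom or an amine on this carbon would read, and so whether the rise from methyl to tert-butyl is a steady climb or a sudden jump.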